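The source may report more compounds than this note shows. Statements on the series, on what has been measured and on what is new or still open speak of the compounds shown alone.

Measured so far in an ADME assay for permeability; on this read-out higher numbers stand for higher permeability and lower numbers for lower permeability:

Compound 1 `CNC(=O)c1cc(C(=O)N[C@H]2CC[C@H](O)CC2)n([C@@H](C)c2ccc(Cl)cc2)n1` gives 180 nm/s.
Compound 2 `CNC(=O)c1cc(C(=O)N[C@H]2CC[C@H](O)CC2)c([C@@H](C)c2ccccc2Cl)o1` gives 78 nm/s.
Compound 3 `CNC(=O)c1cc(C(=O)N[C@H]2CC[C@H](O)CC2)n([C@@H](C)c2ccccc2Cl)n1` gives 100 nm/s.

Compound 4 `CNC(=O)c1cc(C(=O)N[C@H]2CC[C@H](O)CC2)c([C@@H](C)c2ccc(Cl)cc2)o1` has not yet been measured in this assay.

Compounds 3 and 1 share one core and differ by a single change, (4-chlorophenyl in place of 2-chlorophenyl on a saturated chain carbon bound to an aromatic nitrogen and a saturated chain carbon). That change brought a 1.8-fold higher number from compound 3 to compound 1 (0.26 log units; within the scatter), a step that stays within the usual scatter of repeated measurements.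

Compound 4 stands to compound 2 as compound 1 stands to compound 3: the change is 4-chlorophenyl in place of 2-chlorophenyl on a saturated chain carbon bound to an aromatic carbon and a saturated chain carbon. It is the same kind of change, not the same one, since the place differs in what the saturated chain carbon is bound to: an aromatic nitrogen in the first pair, an aromatic carbon in the second. The difference between the cores of compound 2 and compound 3 is not broken down here.

For the measured compounds named here, because the only measured instance of this kind of change gave a 1.8-fold higher number from compound 3 to compound 1 (0.26 log units; within the scatter), a step of a similar size is expected from compound 2 to compound 4, namely a 1.7-fold higher number from compound 2 to compound 4 (0.22 log units; within the scatter). Compound 4 is therefore estimated at 130 nm/s, with a likely range from 70 nm/s to 250 nm/s.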

Compound 4, apparent permeability in the ADME assay: 150 nm/s
For compound 4 the middle estimate is 1.2-fold (0.06 log units) below the measured one; the measured number falls inside the stated range.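

In the ADME assay compound 4 gives 150 nm/s, and putting 4-chlorophenyl in place of 2-chlorophenyl on a saturated chain carbon bound to an aromatic carbon and a saturated chain carbon gave a 1.9-fold higher number from compound 2 to compound 4 (0.28 log units; within the scatter). The same kind of change therefore gave steps of matching size on the two cores: the same change on two cores in the ADME assay, a 1.8-fold higher number (0.26 log units; within the scatter) from compound 3 to compound 1 and a 1.9-fold higher number (0.28 log units; within the scatter) from compound 2 to compound 4, 1.1-fold (0.03 log units) apart, within the scatter of two such steps. For the compounds shown here, each step stays within the scatter, so this shows only that the two cores agree, not that the change gives a real rise in the read-out, and it tells nothing about any other core.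

The compounds shown leave open whether such agreement would hold for a different group, such as 4-methoxyphenyl in place of 4-chlorophenyl. In a physicochemical assay for solubility, measured as kinetic solubility (a higher number here means a more soluble compound, a lower number a less soluble compound), compound 2 gives >= 242 ug/mL, which is a limit of the assay. In the physicochemical assay compound 4 gives >= 118 ug/mL, which is also a limit of the assay. Going by these compounds, the step from compound 2 to compound 4 in the physicochemical assay also stays open: both numbers there are limits of the assay, and the step cannot be read.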